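A few compounds are considered here, and "the series" means these few. Any claim that something is new, unique, unknown or untested is made for them only; others in the source may bear on it.

Measured compounds in a functional assay on HOS cells (Homo sapiens) for inhibition, with a stated time of 72 h; on this read-out higher numbers stand for weaker inhibition and lower numbers for stronger inhibition:
compound 1 `NC1CCC(Nc2nc(NCc3ccc(Br)cc3)c3ncn(C4CCCC4)c3n2)CC1` gives 995 nM
compound 2 `OC1CCC(Nc2nc(NCc3ccc(-c4ccco4)nc3)c3ncn(C4CCCC4)c3n2)CC1` gives 180 nM
compound 3 `CC(C)(O)CNc1nc(NCc2ccc(-c3ccco3)nc2)c2ncn(C3CCCC3)c2n1` gives 560 nM

Compound 1 has the highest of the three numbers in this assay; compound 3 lies within the scatter of it, while compound 2 lies beyond it, though compound 1 and compound 2 differ in more than one place and only their two values can be compared. Among the compounds with values here, the single one-place step, a 3.1-fold higher number from compound 2 to compound 3 (0.49 log units; beyond the scatter), concerns the other ring nitrogen and does not bear on the change at hand. Compound 4 `NC1CCC(Nc2nc(NCc3cc(Cl)ccc3O)c3ncn(C4CCCC4)c3n2)CC1` differs from compound 1 by 5-chloro-2-hydroxyphenyl in place of 4-bromophenyl on a saturated chain carbon bound to a nitrogen on an aromatic ring. Within the data shown here, no measured step covers this change, so nothing supports a move in either direction beyond the scatter. For compound 4 the expected step is therefore a 1.2-fold lower number from compound 1 to compound 4 (0.09 log units; within the scatter), with a wide range. Compound 4 is expected at 800 nM, between 200 nM and 3200 nM.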

Compound 4, half-maximal inhibitory concentration: 490 nM
The estimate for compound 4 lay 1.6-fold (0.21 log units) above the measured number; the range from low to high includes it.
By their numbers in this assay, from the lowest: compound 2; then compounds 4, 3 and 1 (each within the scatter of the next, the first and the last beyond it).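

In this assay, within the data shown here, the step of a 2.0-fold lower number from compound 1 to compound 4 (0.31 log units; beyond the scatter) gives the first reading for a change on a saturated chain carbon bound to a nitrogen on an aromatic ring: 5-chloro-2-hydroxyphenyl in place of 4-bromophenyl lowers the number modestly. Here, the halogen and the added hydroxyl change together, and the step cannot separate them. Nothing on hand gives a cause for this step.

Still open, on these data alone, is how a phenyl carrying only the hydroxyl or only the chlorine would read. Also open, as far as these compounds go, is whether an amine or a carboxylic acid could take the hydroxyl's place.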